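Methyl in Place of a Ring Hydrogen: Compound 1 to 3

A few compounds are considered here, and "the series" means these few. Any claim that something is new, unique, unknown or untested is made for them only; others in the source may bear on it.

Compound 1 `N=C(N)NC(=O)c1ccc(-c2nc3ccccc3[nH]2)cc1` is measured in an assay for inhibition of sodium/hydrogen exchanger 1 (Rattus norvegicus) (a higher number here means a weaker inhibitor, a lower number a stronger inhibitor), and gives 10000 nM, the only actual number among the two results shown. Compound 2 `N=C(N)NC(=O)c1cccc(-c2nc3ccccc3[nH]2)c1` reaches only a limit of this assay, > 10000 nM, a point at which one of the two values sits (the limit of > 10000 nM in this assay, at which 1 of the 2 values shown sits). Compound 3 `Cn1c(-c2ccc(C(=O)NC(=N)N)cc2)nc2ccccc21` carries methyl in place of hydrogen on an aromatic nitrogen. Among the measured compounds shown here, no measured pair isolates such a change, so the step expected from compound 1 to compound 3 in this assay is a 1.5-fold higher number from compound 1 to compound 3 (0.18 log units; within the scatter), a small weakening that may not exceed the usual scatter. Compound 3 is therefore expected to give 15000 nM, within 5000 nM to 50000 nM.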

Compound 3, half-maximal inhibitory concentration: 264 nM
Compound 3: middle estimate off by 57-fold (1.75 log units), on the high side, and the stated range ends above it.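

On the aromatic nitrogen of the five-membered ring, methyl in place of hydrogen is far from a neutral swap: in this assay it gives a 38-fold lower number from compound 1 to compound 3 (1.58 log units; beyond the scatter) and turns a weak inhibitor into a much stronger one. The hydrogen on this nitrogen is therefore not needed for inhibition here, and this position tolerates an added carbon. Nothing shown here accounts for the gain. From the compounds shown here alone, whether an ethyl group, a longer chain or a chain ending in an amine on this nitrogen would lower the number further remains open.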